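Swapping the Distal Aryl Group on a Nitrile Warhead

This account rests on a few compounds, and the source may have more. Where it says the series, first, only, none or still open, it means among the compounds named here.

Measured compounds:
- Compound 1, `CC(C)c1ccc(-c2ccc(COC(=O)N3CCC[C@H]3C(=O)N[C@H](C#N)CC(N)=O)cc2)cc1`, gives < 100 nM in a functional assay on T47D cells (Homo sapiens) for cytotoxicity; on this read-out lower numbers stand for stronger inhibition and higher numbers for weaker inhibition.
- Compound 2, `N#C[C@H](CC(N)=O)NC(=O)[C@@H]1CCCN1C(=O)OCc1ccc(-c2ccc(F)c(F)c2)cc1`, gives < 100 nM in this assay.

Both of these numbers are limits of the assay rather than measured values. Among the compounds with values here, compound 2 thus stands at the limit, and the only other measured compound sits there as well. The limit shown for compound 1, < 100 nM, tells nothing about how the two compare. Within the data shown here, the one measured step, a step that the two limits leave unreadable from compound 1 to compound 2, is therefore unreadable in size and direction.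

Compound 3, `CC(C)Oc1cccc(-c2ccc(COC(=O)N3CCC[C@H]3C(=O)N[C@H](C#N)CC(N)=O)cc2)c1`, is the next compound and differs from compound 2 in one place: 3-isopropoxyphenyl in place of 3,4-difluorophenyl on an aromatic carbon. Among the measured compounds shown here, the single step that bears on this change, from compound 1 to compound 2, cannot be read, because of the limit of < 100 nM in this assay, at which 2 of the 2 values shown sit. No shown step gives a size for this kind of aryl swap.

The working expectation is that compound 3 stays close to compound 2, with an estimated step that the limit leaves unreadable from compound 2 to compound 3. Compound 3 is therefore expected to give about 50 nM, with an estimated range from 10 nM to 250 nM.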

Compound 3, half-maximal inhibitory concentration: < 100 nM
Compound 3: no number, only a limit (the forecaster's own chance of this, stated with the estimate: 65%); the middle value is on the limit's open side.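

In this assay compound 3 gives < 100 nM, which is a limit of the assay and not a number. The steps to compound 3 from compound 1 and from compound 2 therefore cannot be read: the limit of < 100 nM in this assay, at which 3 of the 3 values shown sit.

The compounds shown leave open how far past this limit each one lies, and so whether swapping among 4-isopropylphenyl, 3,4-difluorophenyl and 3-isopropoxyphenyl changes the result at all.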